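This account rests on a few compounds, and the source may have more. Where it says the series, first, only, none or still open, it means among the compounds named here.

Compound 1 `CN(C)C(=O)c1cc2cnc(Nc3ccc(NC(=O)C4(C(=O)Nc5ccc(Cl)cc5)CC4)cc3)nc2n1C1CCCC1` gives 88.6%
Compound 2 `CN(C)C(=O)c1cc2cnc(Nc3ccc(NC(=O)C4(C(=O)Nc5cccc(O)c5)CC4)cc3)nc2n1C1CCCC1` gives 78.5%
Compound 3 `Nc1ccc(NC(=O)C2(C(=O)Nc3ccc(F)cc3)CC2)cc1F` gives 59.2%

These values come from a functional assay on NCI-H1299 cells (Homo sapiens) for inhibition, read by CCK-8 assay, with a stated time of 72 h, tested at 10 uM; a lower number here means less inhibition of growth, a higher number more inhibition of growth at the concentration tested. Among the three, compound 2 stands second highest, below compound 1 and above compound 3, with both gaps beyond the scatter. Compound 4 `CN(C)C(=O)c1cc2cnc(Nc3ccc(NC(=O)C4(C(=O)Nc5ccccc5)CC4)cc3)nc2n1C1CCCC1` has hydrogen in place of hydroxy on an aromatic carbon, meta to a large group: hydrogen in place of hydroxy on an aromatic carbon. Within the data shown here, only one measured step bears on this change. It is a number 10.1 percentage points lower from compound 1 to compound 2 (beyond the scatter), a modest step beyond the scatter in which 3-hydroxyphenyl replaces 4-chlorophenyl on an amide-type nitrogen. Among the measured compounds shown here, that step shows that a change on this ring can shift the number, but no measured compound carries the plain phenyl of compound 4. The direction therefore remains uncertain, and a small rise, within the scatter, is expected: a number 3.5 percentage points higher from compound 2 to compound 4 (within the scatter) is the estimated step. For compound 4 the estimated value is 82%, with an expected range from 71% to 93%.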

Compound 4, percent growth inhibition at one concentration: 90.5%
Compound 4: the middle estimate sits 8.5 percentage points below what was measured; low and high end bracket the measured number.
By their numbers in this assay, from the lowest: compound 3; then compound 2; then compounds 1 and 4 (each within the scatter of the next).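

In this assay, hydrogen in place of hydroxy on the aromatic ring gives a number 12 percentage points higher from compound 2 to compound 4 (beyond the scatter) and so isolates the hydroxy as a change that can be read at this position. Hydrogen in place of chloro gives a number 1.9 percentage points higher from compound 1 to compound 4 (within the scatter) and shows no difference that can be read, so the plain phenyl and the 4-chlorophenyl stand level here, while the 3-hydroxyphenyl stands lower than the plain phenyl. Nothing in the data shown explains why the hydroxy carries this cost.

The compounds shown leave open whether the hydroxy would have the same effect at another place on this ring, and whether chloro at the place held by the hydroxy would match hydrogen. They also leave open how an amine or a carboxylic acid would compare at that same ring carbon.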